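The source may report more compounds than this note shows. Statements on the series, on what has been measured and on what is new or still open speak of the compounds shown alone.

Measured in a functional assay on L1210 cells (Mus musculus) for antiproliferative activity, with a stated time of 48 h; a higher number here means a weaker inhibitor, a lower number a stronger inhibitor:
- compound 1 `C=C(Br)C(=O)Nc1ccc(/C=C/C(=O)c2ccc(OC)cc2)cc1`: 980 nM
- compound 2 `Cc1ccc(C(=O)/C=C/c2ccc(N)cc2)cc1`: 49000 nM

Of these two compounds, compound 2 is the weaker inhibitor in this assay. Its number stands above that of compound 1, and the gap lies beyond the usual scatter. The two differ in more than one place, so the gap says nothing about any single change.

Next is compound 3 `COc1ccc(C(=O)/C=C/c2ccc(N)cc2)cc1`, which differs from compound 2 by one substitution: methoxy in place of methyl on an aromatic carbon. The methoxy takes the place of the methyl on an aromatic carbon, para to a large group. Among the measured compounds shown here, no measured pair isolates this swap, so the expectation is a cautious one. No step beyond the scatter is expected, and the estimated change is a 1.2-fold lower number from compound 2 to compound 3 (0.09 log units; within the scatter). For compound 3 the expected value is 40000 nM, with an estimated range of 15000 nM to 90000 nM.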

Compound 3, half-maximal inhibitory concentration: 160000 nM
The estimate for compound 3 lay 4.0-fold (0.60 log units) below the measured number; measured number above the stated range.
By their numbers in this assay, from the lowest: compound 1; then compound 2; then compound 3.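

In this assay, methoxy in place of methyl on an aromatic carbon, para to a large group, weakens the compound, with a 3.3-fold higher number from compound 2 to compound 3 (0.51 log units; beyond the scatter) showing that this position responds to the swap. Among the compounds shown here, compound 3 also gives the first single-place reading at the nitrogen on the aromatic ring: hydrogen in place of (1-bromoethenyl)carbonyl gives a 160-fold higher number from compound 1 to compound 3 (2.21 log units; beyond the scatter) and marks that group as the larger contributor to potency in the shared core. Nothing on hand explains either step.

From the compounds shown here alone, it remains open whether a hydroxyl or a chlorine on the same aromatic carbon would follow methoxy or methyl, and whether the methoxy-for-methyl step holds once the nitrogen carries (1-bromoethenyl)carbonyl. A plain acetyl on that nitrogen would show how much of the step belongs to the carbonyl and how much to the bromoethenyl part.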